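From Methoxy to Hydroxy: Expected Growth Inhibition of Compound 3

The source may report more compounds than this note shows. Statements on the series, on what has been measured and on what is new or still open speak of the compounds shown alone.

Measured compounds:
Compound 1 `COc1cc(-c2nn(-c3cccc(NC(=O)c4ccc(Cl)c(C(F)(F)F)c4)c3)cc2-c2ccncc2)ccc1Cl` gives 665 nM in a functional assay on HOP-92 cells (Homo sapiens) for inhibition, read by sulforhodamine B assay, with a stated time of 48 h; on this read-out lower numbers stand for stronger inhibition of growth and higher numbers for weaker inhibition of growth.
Compound 2 `COc1cc(-c2nn(-c3cccc(NC(=O)Nc4ccc(Cl)c(C(F)(F)F)c4)c3)cc2-c2ccncc2)ccc1Cl` gives 499 nM in this assay.

Among the compounds with values here, compound 2 holds the lowest of the two numbers, but the only measured step, a 1.3-fold lower number from compound 1 to compound 2 (0.12 log units; within the scatter), lies within the scatter, so the two compounds cannot be ordered. Compound 3 `O=C(Nc1cccc(-n2cc(-c3ccncc3)c(-c3ccc(Cl)c(O)c3)n2)c1)Nc1ccc(Cl)c(C(F)(F)F)c1` differs from compound 2 by hydrogen in place of methyl on an oxygen on an aromatic ring. Within the data shown here, the measured step concerns the carbonyl carbon, not this oxygen, so no measured step bears on the change. Compound 3 is therefore expected to move by a 1.0-fold higher number from compound 2 to compound 3 (0.00 log units; within the scatter), nothing beyond the scatter. Compound 3 is estimated at 500 nM, with a range from 200 nM to 1300 nM.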

Compound 3, concentration for 50% growth inhibition: 376 nM
Estimate against measurement, compound 3: 1.3-fold (0.12 log units) above, and the stated range covers the measured number.
By their numbers in this assay, from the lowest: compounds 3, 2 and 1 (each within the scatter of the next).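

At this oxygen on an aromatic ring, methoxy and hydroxy cannot be told apart in this assay: the first step read at this place, a 1.3-fold lower number from compound 2 to compound 3 (0.12 log units; within the scatter), does not separate them. The methyl is thus not required for a number in this range, at least with the urea-bearing structure of compound 2. No measurement shown here speaks to the cause of this result. The compounds shown leave open how an amine or a longer chain such as ethoxy would read at this place. They also leave open whether hydroxy reads alike on the structure of compound 1.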